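This account rests on a few compounds, and the source may have more. Where it says the series, first, only, none or still open, it means among the compounds named here.

Series notes. Compound 1 `O=C(Nc1nc2ccccc2s1)c1cn(-c2ccccc2)nc1-c1ccccc1` gives 16800 nM in a functional assay on HT-29 cells (Homo sapiens) for cytotoxicity, read by MTT assay, with a stated time of 72 h; a higher number here means a weaker inhibitor, a lower number a stronger inhibitor. Among the measured compounds shown here, compound 2 `O=C(Nc1nc2ccccc2s1)c1cn(-c2ccccc2)nc1-c1ccc(F)cc1` gives 9060 nM in the same assay, the lowest of the two numbers so far; the step of a 1.9-fold lower number from compound 1 to compound 2 (0.27 log units; within the scatter) is fluoro in place of hydrogen on an aromatic carbon. Compound 3 `O=C(Nc1nc2ccc(Cl)cc2s1)c1cn(-c2ccccc2)nc1-c1ccc(F)cc1` carries the change (chloro in place of hydrogen on an aromatic carbon), on the other ring system of the shared core. For the measured compounds named here, no measured step touches that ring; the only step known, from compound 1 to compound 2, is a halogen addition elsewhere and lay within the scatter. Compound 3 is therefore expected to move by a 1.3-fold lower number from compound 2 to compound 3 (0.11 log units; within the scatter), not beyond the scatter, with an estimate of 7000 nM (range 2500 nM to 20000 nM).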

Compound 3, half-maximal inhibitory concentration: 3320 nM
Beside the measured number, compound 3's estimate is 2.1-fold (0.32 log units) above it; low and high end bracket the measured number.
By their numbers in this assay, from the lowest: compound 3; then compounds 2 and 1 (each within the scatter of the next).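

Among the compounds shown here, the step of a 2.7-fold lower number from compound 2 to compound 3 (0.44 log units; beyond the scatter) is the first to lie beyond the scatter, whereas the fluoro change a 1.9-fold lower number from compound 1 to compound 2 (0.27 log units; within the scatter) stayed within it. It shows that in this assay the number responds, modestly and in this one pair, to chloro on an aromatic carbon of the six-membered ring of carbon only, the change from 1,3-benzothiazol-2-yl to 6-chloro-1,3-benzothiazol-2-yl. No evidence available here accounts for this shift.

Going by these compounds, whether a methoxy group, an amine or a carboxylic acid at this position would move the number the same way remains open. Also open, on these data alone, is whether chloro gives a similar step on compound 1, which lacks the fluoro.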